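Fluoro substitution on the fused ring of compound 1

The source may report more compounds than this note shows. Statements on the series, on what has been measured and on what is new or still open speak of the compounds shown alone.

Measured compounds:
compound 1 `Cc1cccc(N2CCN(CCCNc3nc(NCc4ccco4)c4ccccc4n3)CC2)c1C`: 94%
compound 2 `CCCCCNc1nc(NCc2ccco2)c2cc(F)ccc2n1`: "not determined" (no result reported)

Within the data shown here, compound 1 is the only compound of the series with a number in a functional assay on HT-29 cells (Homo sapiens) for cytotoxicity, read by MTT assay, with a stated time of 2 days, tested at 10 uM; on this read-out lower numbers stand for less inhibition and higher numbers for more inhibition at the one concentration tested (going by the name of the read-out); in this assay compound 1 gives 94%. Compound 2 shares the furanylmethylamino group and carries fluoro on its fused ring, but no result was reported for it, so it offers no comparison. Among the measured compounds shown here, no step between two measured compounds exists.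

Compound 3 `Cc1cccc(N2CCN(CCCNc3nc(NCc4ccco4)c4cc(F)ccc4n3)CC2)c1C` differs from compound 1 by fluoro in place of hydrogen on an aromatic carbon. With a single heavy atom entering and compound 1 already high on the read-out, the step from compound 1 to compound 3 is expected to lie within the usual scatter, with no direction favoured. Compound 3 is therefore estimated at 91%, with a range of 78% to 99%, and the expected step is a number 3 percentage points lower from compound 1 to compound 3 (within the scatter).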

Compound 3, a percentage reported as inhibition, at one concentration (the size of the read-out at that concentration, not a potency): 96.7%
Compound 3: middle estimate off by 5.7 percentage points, on the low side; the range from low to high includes it.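

In this assay, among these compounds, fluoro in place of hydrogen on an aromatic carbon gives a number 2.7 percentage points higher from compound 1 to compound 3 (within the scatter), the first readable step, as compound 2 offers no result. This position, meta to a fused ring and para to a fused ring, therefore accepts fluoro on the core of compound 1 with no change in the read-out beyond the scatter. No measurement is available that bears on the reason for this result.

On these data alone, whether a larger change at this position, such as chloro, methoxy or an amine, would move the read-out beyond the scatter remains open. As far as these compounds go, with a reading at one concentration and no potency, any difference between compound 1 and compound 3 at other concentrations also remains open.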